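The source may report more compounds than this note shows. Statements on the series, on what has been measured and on what is new or still open speak of the compounds shown alone.

Compound 2: `O=C(CCCCCc1ccc(Cl)cc1)N1CCOC1=O` — 4600 nM
Compound 1: `O=C(CCCCCc1cccc(CO)c1)N1CCOC1=O` — > 20000 nM

In an assay on HEK293 cells for inhibition of N-acylethanolamine-hydrolyzing acid amidase (Rattus norvegicus), read by LC-MS, with a stated time of 30 min (a lower number here means a stronger inhibitor, a higher number a weaker inhibitor), compound 2 gives 4600 nM. Compound 1 is reported only as a limit of the assay, > 20000 nM, and not as a number. Among the compounds with values here, compound 2 therefore holds the only measured number in this assay, while the other entry sits at the limit of > 20000 nM in this assay, at which 1 of the 2 values shown sits. Within the data shown here, because the two compounds differ in more than one place, no single step between them is counted, and the pair says only that compound 2 gives a measured value where compound 1 does not.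

Compound 3, `O=C(CCCCCc1ccc(I)cc1)N1CCOC1=O`, is not yet measured. It differs from compound 2 by iodo in place of chloro on an aromatic carbon. The data hold no measured exchange of one halogen for another, so no step size is given; the writer expects a change no larger than a modest gain in potency in this assay, and possibly none beyond the scatter. The step from compound 2 to compound 3 is estimated as a 1.8-fold lower number from compound 2 to compound 3 (0.26 log units; within the scatter). On that basis compound 3 is expected to give about 2500 nM in this assay, within a range of 800 nM to 8000 nM.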

Compound 3, half-maximal inhibitory concentration: > 20000 nM
Compound 3 gave a limit, no number; the forecaster's own chance of this, stated with the estimate: 5%; middle value at least 8.0-fold (0.90 log units) away from the limit.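

Exchanging chloro for iodo on an aromatic carbon para to a large group swaps one heavy atom for one heavy atom, yet in this assay it gives an at least 4.3-fold higher number from compound 2 to compound 3 (0.63 log units; beyond the scatter). Within the data shown here, this is the first single-place comparison in the set, and it shows that the outcome at this position depends on which halogen sits there: a measured number is kept with chloro and lost with iodo. Compound 3 is reported only as a limit of the assay, which leaves compound 2 as the only compound of the three with a measured number: the limit of > 20000 nM in this assay, at which 2 of the 3 values shown sit.

On these data alone, the two halogens alone do not show how the result changes across other groups at this position, so it remains open whether fluoro, bromo, methyl or methoxy would give a measured number in this assay, and where any of them would fall relative to compound 2. As far as these compounds go, it is also open how far compound 3 lies past its limit, and whether a shorter or longer chain on the shared core would bring an iodo compound back to a measurable number.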